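The source may hold more compounds than are shown below. What is called first, only, known or untested is meant among the compounds shown, and "the series" means these compounds.

Measured so far in a physicochemical assay for solubility, measured as kinetic solubility, with a stated time of 15 h, at pH 7.4; on this read-out higher numbers stand for higher solubility and lower numbers for lower solubility:
compound 1 `OC[C@H]1O[C@H](Oc2ccc(-c3ccccc3Cl)cc2Cl)[C@@H](O)[C@@H](O)[C@@H]1O`: 28 ug/mL
compound 2 `OC[C@H]1O[C@H](Oc2ccc(-c3ccccc3)cc2Cl)[C@@H](O)[C@@H](O)[C@@H]1O`: 5.5 ug/mL

On these two numbers compound 1 stands highest; the nearest number is a 5.1-fold lower number from compound 1 to compound 2 (0.71 log units; beyond the scatter), the step being hydrogen in place of chloro on an aromatic carbon. Compound 3 `CC(=O)c1ccc(-c2ccc(O[C@H]3O[C@H](CO)[C@@H](O)[C@H](O)[C@@H]3O)c(Cl)c2)cc1` has not yet been measured in this assay. Relative to compound 1 the change is 4-acetylphenyl in place of 2-chlorophenyl on an aromatic carbon. Among the compounds with values here, the one measured step that bears on this is a 5.1-fold lower number from compound 1 to compound 2 (0.71 log units; beyond the scatter), which also removed the chloro from the ring that leaves; that step lowered the number modestly and beyond the scatter. Within the data shown here, no measured step shows what the 4-acetylphenyl that enters does on this read-out, so the acetyl part of the change is uncovered. Taking the chloro removal as the only guide, a lowering of the number is expected for compound 3, though less certain than in the measured pair. The expected step is a 2.3-fold lower number from compound 1 to compound 3 (0.37 log units; beyond the scatter). Compound 3 is estimated at 12 ug/mL, with a range from 4 ug/mL to 40 ug/mL.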

Compound 3, solubility: 16 ug/mL
Compound 3: middle estimate off by 1.3-fold (0.12 log units), on the low side; the measured number falls inside the stated range.
By their numbers in this assay, from the lowest: compound 2; then compounds 3 and 1 (each within the scatter of the next).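

In this assay, the aromatic carbon para to a large group now carries a second substituted phenyl, and the step of a 1.8-fold lower number from compound 1 to compound 3 (0.24 log units; within the scatter) means that 4-acetylphenyl and 2-chlorophenyl cannot be told apart on this read-out. The earlier pair showed only what happened when chloro gave way to hydrogen, whereas acetyl in place of hydrogen gives a 2.9-fold higher number from compound 2 to compound 3 (0.46 log units; beyond the scatter) and so extends the picture beyond chloro: among the three compounds, the unsubstituted phenyl of compound 2 has the lowest number, and neither substituted compound goes against this. Nothing measured on these compounds explains the numbers.

Because compound 1 and compound 3 differ in both the substituent and its place on the phenyl, the effects of group and place remain unseparated, and a 4-chlorophenyl or a 2-acetylphenyl would be needed to divide them. From the compounds shown here alone, it also remains open whether the higher numbers hold for other groups on this phenyl, such as an amine, a carboxylic acid or a longer chain in place of the acetyl.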